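A few compounds are considered here, and "the series" means these few. Any claim that something is new, unique, unknown or untested is made for them only; others in the source may bear on it.

Measured compounds:
- Compound 1, `CN(C)CCN(C)CCCCOc1ccccc1/C=C/c1ccccc1`: in a functional assay on the whole organism with Mus musculus as the target, in the maximal electroshock model, at a dose of 50 mg/kg by the oral route (a lower number here means less inhibition, a higher number more inhibition at the dose given (going by the name of the read-out)), compound 1 gives 0%.
- Compound 2, `CCCOC1CCCN(CCCCOc2ccccc2/C=C/c2ccccc2)C1`: in this assay compound 2 gives 0%.

Compound 2 stands level with compound 1 at the digits shown. The two compounds share the same core and differ only in the amine-bearing chain, yet both give the same reading in this assay, and the gap between them lies within the usual scatter of repeated measurements. Going by the values given here, no step between measured compounds is therefore available as a guide.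

Compound 3, `OCC1CCCN(CCCCOc2ccccc2/C=C/c2ccccc2)C1`, differs from compound 2 in one place: hydroxymethyl in place of propoxy on a saturated ring carbon. The change sits at the same end of the molecule where compound 1 and compound 2 already differ without any shift in this assay. The expected step from compound 2 to compound 3 is therefore no change at the digits printed from compound 2 to compound 3 (within the scatter), that is, none beyond the scatter, because compound 2 gives 0% and compound 1 gives 0% at the same dose.

Compound 3 is expected to give 0% in this assay, with a range from 0% to 15%.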

Compound 3, a percentage reported as inhibition, in the whole organism at one dose (the size of the read-out at that dose, not a potency): 12.5%
Compound 3: middle estimate off by 12.5 percentage points, on the low side; the range from low to high includes it.
By their numbers in this assay, from the lowest: compounds 1 and 2 (each within the scatter of the next); then compound 3.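

Replacing propoxy with hydroxymethyl on this saturated ring carbon, two ring bonds from the ring nitrogen, gives a number 12.5 percentage points higher from compound 2 to compound 3 (beyond the scatter) in this assay and shows that the group at this position can alter the reading, which the level results for compound 1 and compound 2 gave no sign of. The wider replacement of (2-(dimethylamino)ethyl)(methyl)amino by 3-(hydroxymethyl)piperidin-1-yl gives a number 12.5 percentage points higher from compound 1 to compound 3 (beyond the scatter) and so shows the same rise against the other compound at the bottom of the scale. Nothing measured here explains why the reading rises.

On these data alone, the change from compound 2 to compound 3 alters two things at once, with fewer heavy atoms in the group and a hydrogen-bond donor gained, so it remains open which of these goes with the step, and a methoxymethyl group or a hydroxyethyl group at the same carbon would help to tell them apart. Also open, as far as these compounds go, is how the reading would respond to an aminomethyl group or a carboxylic acid there, and how compound 3 would behave at other doses, since a single-dose reading is not a potency.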